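The source may hold more compounds than are shown below. What is called first, only, known or untested is meant among the compounds shown, and "the series" means these compounds.

Three measured compounds set the scene. Compound 1 `CCCC(=O)c1ccc(OCCCCOc2ccc(F)c(C(=O)O)c2)c(C)c1O` in an assay on HEK293 cells for positive allosteric modulation of metabotropic glutamate receptor 2 (Rattus norvegicus), read by thallium flux, with a stated time of 2.5 min (on this read-out higher numbers stand for larger maximal responses and lower numbers for smaller maximal responses), reaches 87.5%. Compound 3 `Cc1c(OCCCCOc2ccc(C(=O)O)cc2Cl)ccc(C(=O)CC(C)C)c1O` reaches 99.5% in this assay, a number that lies higher than that of compound 1 by more than the usual scatter, while compound 2 `Cc1c(OCCCCOc2cccc(C(=O)O)c2)ccc(C(=O)CC(C)C)c1C` reaches only 12.1% in this assay. Among the three numbers, compound 1 therefore stands second highest, closest to compound 3 and far from compound 2.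

The next compound, compound 4 `Cc1c(OCCCCOc2ccc(F)c(C(=O)O)c2)ccc(C(=O)C(C)C)c1O`, keeps the same atoms as compound 1 but joins them differently. The change is isopropyl in place of propyl on a carbonyl carbon: the same three carbons remain on the carbonyl carbon, only their arrangement shifts from a straight chain to a branched one.

Among the compounds with values here, no pair of measured compounds shows this single change, so the size of its effect cannot be read from the data. The expectation is a step from compound 1 to compound 4 of a number 2.5 percentage points lower from compound 1 to compound 4 (within the scatter), within the usual scatter. Compound 4 is therefore estimated to reach 85% in this assay, with a plausible range from 65% to 100%.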

Compound 4, largest response reached (reported as percent of maximum), in percent of the reference or control that the assay uses: 74.1%
Compound 4: the middle estimate sits 10.9 percentage points above what was measured; the measured number falls inside the stated range.
By their numbers in this assay, from the lowest: compound 2; then compound 4; then compound 1; then compound 3.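

Within the data shown here, the change from propyl to isopropyl on a carbonyl carbon gives the first single-place comparison in this assay, and it reads a number 13.4 percentage points lower from compound 1 to compound 4 (beyond the scatter). The same three carbons remain at this position, so their arrangement alone is enough to move the maximal response, although the step is modest and compound 4 still gives 74.1%. Nothing available explains why the branched group gives the lower number.

As far as these compounds go, it remains open whether a tert-butyl or cyclopropyl group on the same carbonyl carbon would lower the response further or restore it. This single pair also cannot show whether the switch from propyl to isopropyl would have a similar effect in compounds that differ elsewhere in the structure.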